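Thiosemicarbazide amidrazones: removing the ring methyl

The compounds below may be only part of what the source reports. "The series", "measured", "known", "first", "only" and "open" are said of these compounds alone.

Compound 1 `Cc1cccc(/C(N)=N/NC(=S)N2CCN(c3ccccn3)CC2)n1` and compound 2 `N/C(=N\NC(=S)N1CCCC1)c1ccccn1` have been run in a functional assay on A-431 cells (Homo sapiens) for cytotoxicity, read by MTT assay, with a stated time of 72 h, tested at 10 uM; a higher number here means more inhibition of growth at the concentration tested, a lower number less inhibition of growth. Compound 1 gives 43%, while compound 2 gives 77.2%. Going by the values given here, of the two numbers, compound 1 stands lowest; the nearest and only neighbour, compound 2, lies beyond the scatter above it, and no single-change step links these two compounds, so their values are compared only as they stand.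

Compound 3 `N/C(=N\NC(=S)N1CCN(c2ccccn2)CC1)c1ccccn1` is not yet measured. It differs from compound 1 by hydrogen in place of methyl on an aromatic carbon, the change sitting on the 6-methylpyridin-2-yl group, which becomes pyridin-2-yl. Among the compounds with values here, compound 2 also carries the unsubstituted pyridin-2-yl amidrazone, but it differs from compound 1 in a second place as well, so it sets no clean step.

A modest rise, beyond the scatter, is expected for a number 12 percentage points higher from compound 1 to compound 3 (beyond the scatter). Compound 3 is estimated at 55%, within a range from 30% to 78%.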

Compound 3, percent growth inhibition at one concentration: 69%
For compound 3 the middle estimate is 14 percentage points below the measured one, within the range that was stated.
By their numbers in this assay, from the lowest: compound 1; then compounds 3 and 2 (each within the scatter of the next).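

In this assay the change from 6-methylpyridin-2-yl to pyridin-2-yl gives a number 26 percentage points higher from compound 1 to compound 3 (beyond the scatter) on its own, so the aromatic carbon next to the ring nitrogen is a position where this read-out responds to a single methyl. Compound 3 keeps everything else of compound 1, and compound 3 at 69% lies within the scatter of compound 2 at 77.2% in this series, so removing the methyl alone closes the gap seen between compound 1 and compound 2. Nothing on hand accounts for the step, which stands here as an observation only.

On these data alone, whether a methoxy group, an ethyl group or an amine at this position would stay with compound 3 or fall towards compound 1 remains open. Also open, as far as these compounds go, is whether adding the same methyl to compound 2 would give a step of similar size, as this single pair cannot show whether the step carries over.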